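Ethoxy at the amidine carbon of the quinazoline-type core

The compounds below may be only part of what the source reports. "The series", "measured", "known", "first", "only" and "open" are said of these compounds alone.

Measured so far:
compound 1 `COc1ccc2c(c1)NC(=O)CN2c1nc(Nc2ccc(C#N)cc2)nc2ccccc12` 6.17 nM
compound 2 `COc1ccc2c(c1)NC(=O)CN2c1nc(COC(C)=O)nc2ccccc12` 5.52 nM

Both numbers come from a functional assay on A549 cells (Homo sapiens) for inhibition, read by sulforhodamine B assay, with a stated time of 48 h; a higher number here means a weaker inhibitor of growth, a lower number a stronger inhibitor of growth. Compound 1 stands together with compound 2; the two values are separated only by a 1.1-fold lower number from compound 1 to compound 2 (0.05 log units; within the scatter), so neither can be set apart from the other on these data.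

Compound 3 `CCOc1nc(N2CC(=O)Nc3cc(OC)ccc32)c2ccccc2n1` is not yet measured. It departs from compound 1 as follows: ethoxy in place of (4-cyanophenyl)amino on an aromatic carbon.

Among the compounds with values here, only one measured step bears on this change, the one in which the same group left compound 1, namely a 1.1-fold lower number from compound 1 to compound 2 (0.05 log units; within the scatter). There, replacing the (4-cyanophenyl)amino group by acetoxymethyl left the growth-inhibition number where it was. Nothing measured speaks to ethoxy itself, so the expectation rests on that single step alone.

For compound 3 the step from compound 1 is therefore expected to be a 1.1-fold higher number from compound 1 to compound 3 (0.05 log units; within the scatter), with nothing beyond the scatter foreseen. The estimate for compound 3 in this assay is 7 nM, with the range 2.5 nM to 20 nM.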

Compound 3, concentration for 50% growth inhibition: 16.7 nM
For compound 3 the middle estimate is 2.4-fold (0.38 log units) below the measured one; low and high end bracket the measured number.
By their numbers in this assay, from the lowest: compounds 2 and 1 (each within the scatter of the next); then compound 3.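

This position does respond to what it carries. Ethoxy gives a 2.7-fold higher number from compound 1 to compound 3 (0.43 log units; beyond the scatter) and a 3.0-fold higher number from compound 2 to compound 3 (0.48 log units; beyond the scatter), whereas (4-cyanophenyl)amino and acetoxymethyl could not be told apart, so the earlier pair gave no sign of this sensitivity. A ring in the group does not separate compound 3 from the other two, as compound 2 carries none and still stands with compound 1, and nothing available accounts for the shift.

On these data alone, whether a longer alkoxy chain such as butoxy, or a methoxy group, would move the number further from or back towards that of compound 1 remains open. So does the effect of a simple amine or a carboxylic acid at this carbon, and with it whether the oxygen directly on the ring matters at all.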